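Replacing 4-methoxybenzyl with butyl on the shared core

The compounds below may be only part of what the source reports. "The series", "measured", "known", "first", "only" and "open" are said of these compounds alone.

In an ADME assay on KB cells (Homo sapiens) for cytotoxicity (on this read-out higher numbers stand for an effect only at larger amounts of compound and lower numbers for an effect already at smaller amounts), compound 1 (`CCCOc1c(OC)c(OC)cc2c1C(=O)[C@]1(OC)C=C[C@H]2N(C(=O)OCC)N1C(=O)OCC`) gives > 300 ug/mL as a limit of the assay and not a number. Going by the values given here, compound 2 (`CCOC(=O)N1[C@@H]2C=C[C@@](OC)(C(=O)c3c2cc(OC)c(OC)c3OCc2ccc(OC)cc2)N1C(=O)OCC`) gives 63.1 ug/mL as the only true number so far. Compound 3 (`CCCCOc1c(OC)c(OC)cc2c1C(=O)[C@]1(OC)C=C[C@H]2N(C(=O)OCC)N1C(=O)OCC`) carries propyl in place of 4-methoxyphenyl on a saturated chain carbon bound to an oxygen on an aromatic ring. Among the compounds with values here, one measured step bears on this and runs the other way, with 4-methoxyphenyl taking the place of ethyl: it is an at least 4.7-fold lower number from compound 1 to compound 2 (0.67 log units; beyond the scatter) and lies beyond the scatter, so a rise of similar size is expected for the reverse kind of change. The expected step is a 3.2-fold higher number from compound 2 to compound 3 (0.50 log units; beyond the scatter) in this assay with propyl as the entering chain. For compound 3 the estimate is 200 ug/mL with an expected range from 70 ug/mL to 500 ug/mL as the likely span.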

Compound 3, concentration for half-maximal effect: 76 ug/mL
Estimate against measurement, compound 3: 2.6-fold (0.42 log units) above; low and high end bracket the measured number.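

In this assay, butoxy in place of (4-methoxybenzyl)oxy gives a 1.2-fold higher number from compound 2 to compound 3 (0.08 log units; within the scatter), so at this place a chain without a ring does as well as the 4-methoxybenzyl group. The chain's length does count: methyl in place of hydrogen on a saturated chain carbon, three bonds along the chain from an oxygen on an aromatic ring, gives an at least 3.9-fold lower number from compound 1 to compound 3 (0.59 log units; beyond the scatter), a step beyond the scatter that ties the lower number to a single added carbon. Its full size is not known, as compound 1 gives a limit of the assay and not a number: the limit of > 300 ug/mL in this assay, at which 1 of the 3 values shown sits.

On these data alone, whether a longer chain such as hexyl would lower the number further remains open. So does the effect of an amine or a carboxylic acid at the end of the chain.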